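The source may report more compounds than this note shows. Statements on the series, on what has been measured and on what is new or still open speak of the compounds shown alone.

Notes on the series in an assay on HeLa cells for inhibition of Kinesin-like protein KIF15 (Homo sapiens), read by microscopy, with stated times of 2 s and 20 s, tested at 750 nM; a higher number here means more inhibition at the concentration tested (going by the name of the read-out), a lower number less inhibition.

Two compounds have numbers. Compound 1, `O=C1Nc2ccc(C(=O)c3ccco3)cc2/C1=C/c1cc(Br)cc(Br)c1`, gives 16% in this assay. Compound 2, `O=C1Nc2ccc(C(=O)N3CCCC3)cc2/C1=C/c1cc(Cl)c(O)c(Cl)c1`, gives -10% in this assay and so stands lowest of the two; its nearest neighbour is compound 1, whose number lies higher by a margin beyond the usual scatter. Among the compounds with values here, no step between compounds differing in a single place is available in this pair, so the two numbers are simply read side by side.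

Compound 3, `O=C1Nc2ccc(I)cc2/C1=C/c1cc(Cl)c(O)c(Cl)c1`, is not yet measured. It differs from compound 2 in one place: iodo in place of (pyrrolidin-1-yl)carbonyl on an aromatic carbon. Within the data shown here, with no comparable step in hand, the step from compound 2 to compound 3 is expected to be small and, if anything, upward, though it may well sit within the scatter, so a number 18 percentage points higher from compound 2 to compound 3 (beyond the scatter) is the working guess. On that basis compound 3 is estimated at 8%, with a range from -15% to 35%.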

Compound 3, a percentage reported as inhibition, at one concentration (the size of the read-out at that concentration, not a potency): 15%
The estimate for compound 3 lay 7 percentage points below the measured number; measured number inside the range.
By their numbers in this assay, from the lowest: compound 2; then compounds 3 and 1 (each within the scatter of the next).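

Iodo in place of (pyrrolidin-1-yl)carbonyl on an aromatic carbon gives a number 25 percentage points higher from compound 2 to compound 3 (beyond the scatter) in this assay and provides the first comparison in this series in which only one place changes. With the rest of the molecule held constant, the read-out responds to the group at this position, meta to a fused ring and para to a fused ring, when a single iodine replaces a group of 7 heavy atoms containing a five-membered non-aromatic ring. No supporting measurement accounts for the size or direction of this step.

The compounds shown leave open whether the step follows from the departure of the (pyrrolidin-1-yl)carbonyl or from the arrival of iodo. Bromo, a carboxylic acid or a primary amine at this position would help separate those two readings.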